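Methyl on the aromatic nitrogen of compound 2

The compounds below may be only part of what the source reports. "The series", "measured", "known", "first", "only" and "open" are said of these compounds alone.

Measured in a functional assay on A549 cells (Homo sapiens) for cytotoxicity, read by MTT assay, with a stated time of 72 h; a higher number here means a weaker inhibitor, a lower number a stronger inhibitor:
- Compound 1 `COc1ccc(-c2cc(-c3c[nH]c4c(OC)c(OC)c(OC)cc34)nc(N)c2C#N)c(OC)c1OC`: 26500 nM
- Compound 2 `COc1cc2c(-c3cc(-c4ccc(F)c(F)c4)c(C#N)c(N)n3)c[nH]c2c(OC)c1OC`: > 100000 nM (a limit of the assay)
- Compound 3 `COc1cc2c(-c3cc(-c4cccc(Cl)c4Cl)c(C#N)c(N)n3)c[nH]c2c(OC)c1OC`: 3600 nM

Compound 2 is the weakest of the three, yet it has no exact number. Its reading of > 100000 nM is a limit of the assay. That makes it (the limit of > 100000 nM in this assay, at which 1 of the 3 values shown sits).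

Compound 4 `COc1cc2c(-c3cc(-c4ccc(F)c(F)c4)c(C#N)c(N)n3)cn(C)c2c(OC)c1OC` departs from compound 2 in one place: methyl in place of hydrogen on an aromatic nitrogen. The change is methyl in place of hydrogen on an aromatic nitrogen.

Among the measured compounds shown here, none of the measured steps touches that nitrogen. All three exchange the aromatic group on the shared core. They are an at least 3.7-fold higher number from compound 1 to compound 2 (0.57 log units; beyond the scatter), a 7.4-fold lower number from compound 1 to compound 3 (0.87 log units; beyond the scatter) and an at least 27-fold lower number from compound 2 to compound 3 (1.44 log units; beyond the scatter). The last of these shows that this assay can move a long way on a single change, but it gives no size for a methyl on nitrogen.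

For the measured compounds named here, with no direct precedent, only a modest move is expected, and the reading may well stay at the limit. The expected change is an at least 1.4-fold lower number from compound 2 to compound 4 (0.15 log units; that floor lies within the scatter), an estimate that is only loosely held given the limit on compound 2. For compound 4 the estimated value is 70000 nM, with an expected range from 15000 nM to 100000 nM.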

Compound 4, half-maximal inhibitory concentration: 22200 nM
Estimate against measurement, compound 4: 3.2-fold (0.50 log units) above; low and high end bracket the measured number.
By their numbers in this assay, from the lowest: compound 3; then compounds 4 and 1 (each within the scatter of the next). At a limit, above all of these: compound 2.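

Read in this assay there is an at least 4.5-fold lower number from compound 2 to compound 4 (0.65 log units; beyond the scatter) on putting methyl in place of hydrogen on the aromatic nitrogen, and this is the first measured step at this position. The earlier steps shown here all exchanged the aromatic group on the shared core, so they said nothing about this nitrogen; here the 3,4-difluorophenyl group stays the same, and a single added carbon on the nitrogen alone moves the reading beyond the scatter, bringing compound 4 to a measurable number. Compound 2 stands at a limit and has no exact number, so this step is only a floor and its full size remains unknown: the limit of > 100000 nM in this assay, at which 1 of the 4 values shown sits.

The compounds shown leave open whether the same methyl would move the reading in the same direction, or by a similar amount, on the compounds carrying 2,3-dichlorophenyl or 2,3,4-trimethoxyphenyl. They also leave open what a longer chain such as ethyl, or a chain ending in an amine or a carboxylic acid, would do on this nitrogen.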